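Cyclopentyl for 2-chlorophenyl on the ring nitrogen

The source may hold more compounds than are shown below. What is called first, only, known or untested is meant among the compounds shown, and "the series" means these compounds.

Among the measured compounds shown here, the three measured members share one core and differ only in the group on an aromatic nitrogen. Compound 1 `C=CC(=O)Nc1cc(Nc2ncc3ncn(-c4ccc(CC)cc4)c3n2)c(OC)cc1N(C)CCN(C)C` gives 8180 nM in an ADME assay on HT-29 cells (Homo sapiens) for cytotoxicity, read by MTT assay, with a stated time of 72 h; on this read-out lower numbers stand for stronger inhibition and higher numbers for weaker inhibition; compound 2 `C=CC(=O)Nc1cc(Nc2ncc3ncn(-c4ccc(Cl)cc4)c3n2)c(OC)cc1N(C)CCN(C)C` gives 7690 nM; compound 3 `C=CC(=O)Nc1cc(Nc2ncc3ncn(-c4ccccc4Cl)c3n2)c(OC)cc1N(C)CCN(C)C` gives 11300 nM. Compound 3 carries the highest of the three numbers, yet a 1.4-fold higher number from compound 1 to compound 3 (0.14 log units; within the scatter) and a 1.5-fold higher number from compound 2 to compound 3 (0.17 log units; within the scatter) both stay within the scatter, as does a 1.1-fold lower number from compound 1 to compound 2 (0.03 log units; within the scatter). Compound 4 `C=CC(=O)Nc1cc(Nc2ncc3ncn(C4CCCC4)c3n2)c(OC)cc1N(C)CCN(C)C` brings (cyclopentyl in place of 2-chlorophenyl on an aromatic nitrogen). For the measured compounds named here, no measured step exchanges a substituted phenyl for a non-aromatic ring; the three known steps each swap one substituted phenyl for another, and none moved the read-out beyond the scatter. The expected step is therefore a 1.1-fold lower number from compound 3 to compound 4 (0.05 log units; within the scatter), not beyond the scatter. Compound 4 is estimated at 10000 nM, with a range from 4500 nM to 22000 nM.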

Compound 4, half-maximal inhibitory concentration: 20900 nM
Compound 4: the middle estimate sits 2.1-fold (0.32 log units) below what was measured, and the stated range covers the measured number.
By their numbers in this assay, from the lowest: compounds 2, 1, 3 and 4 (each within the scatter of the next, the first and the last beyond it).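

In this assay, among the compounds shown here, the non-aromatic cyclopentyl on the aromatic nitrogen gives the first steps at this position beyond the scatter: a 2.7-fold higher number from compound 2 to compound 4 (0.43 log units; beyond the scatter) and a 2.6-fold higher number from compound 1 to compound 4 (0.41 log units; beyond the scatter) are both modest and both start from a 4-substituted phenyl. Compound 3 goes against a general phenyl-to-cyclopentyl pattern, since a 1.8-fold higher number from compound 3 to compound 4 (0.27 log units; within the scatter) stays within the scatter. No measurement on hand accounts for these steps.

Open: whether an open chain such as isopropyl, or a non-aromatic ring carrying an amine such as piperidine, on this nitrogen reads like cyclopentyl or like the substituted phenyls.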